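Swapping the pyridine for a methylphenyl ring

A few compounds are considered here, and "the series" means these few. Any claim that something is new, unique, unknown or untested is made for them only; others in the source may bear on it.

Measured compounds in a functional assay on HCT-15 cells (Homo sapiens) for cytotoxicity, in the presence of a further agent that is not named here; a higher number here means a weaker inhibitor, a lower number a stronger inhibitor:
- compound 1 `Clc1ccc(-c2cc(-c3cccnc3)nc(-c3cccs3)c2)o1`: 1240 nM
- compound 2 `Clc1ccc(-c2cc(-c3cccnc3)nc(-c3ccsc3)c2)o1`: > 50000 nM
- compound 3 `Cc1ccc(-c2cc(-c3ccc(Cl)o3)cc(-c3ccsc3)n2)o1`: > 50000 nM

For the measured compounds named here, compound 1 is the only compound of the three for which this assay returned an actual number. For compound 2 the value is a limit of the assay, not a number. For compound 3 the value is likewise a limit, not a number (the limit of > 50000 nM in this assay, at which 2 of the 3 values shown sit).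

Compound 4 `Cc1ccc(-c2cc(-c3ccc(Cl)o3)cc(-c3cccs3)n2)cc1` has not yet been measured. It differs from compound 1 in one place: 4-methylphenyl in place of pyridin-3-yl on an aromatic carbon. The thiophen-2-yl group and the 5-chlorofuran-2-yl group of compound 1 remain unchanged.

Going by the values given here, of the measured steps, only the one from compound 2 to compound 3 touches the pyridin-3-yl group, and a step that the two limits leave unreadable from compound 2 to compound 3, so it gives no reading. The step of an at least 40-fold higher number from compound 1 to compound 2 (1.60 log units; beyond the scatter) concerns the thiophene and says nothing about the pyridin-3-yl group. The new change is therefore without a measured precedent here.

Given that lack of guidance, compound 4 is estimated to lie near compound 1, at 2000 nM, with a wide range from 500 nM to 20000 nM. This estimate means a step of a 1.6-fold higher number from compound 1 to compound 4 (0.21 log units; within the scatter) that is expected to stay within the scatter.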

Compound 4, half-maximal inhibitory concentration: 9890 nM
Beside the measured number, compound 4's estimate is 4.9-fold (0.69 log units) below it; measured number inside the range.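

This position now has its first readable step: in this assay, putting 4-methylphenyl in place of pyridin-3-yl, on the aromatic carbon next to the ring nitrogen of the core, gives an 8.0-fold higher number from compound 1 to compound 4 (0.90 log units; beyond the scatter). The group at this position therefore matters to the read-out, although the swap changes two things at once, as the ring nitrogen with its hydrogen-bond acceptor leaves and a methyl group enters. Even so, compound 4 gives an actual number and does not sit at the limit, which is a boundary of the assay rather than a measured value: the limit of > 50000 nM in this assay, at which 2 of the 4 values shown sit.

The compounds shown leave open whether the loss of the ring nitrogen or the arrival of the methyl group accounts for the step, and a plain phenyl ring at this position would help to separate the two. Also open, from the compounds shown here alone, is how this position would respond to a 4-aminophenyl or 4-carboxyphenyl group, and whether the same swap would read the same way with the thiophen-3-yl group in place of the thiophen-2-yl group.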